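Swapping the chain on the amide of compound 3

This account rests on a few compounds, and the source may have more. Where it says the series, first, only, none or still open, it means among the compounds named here.

Compound 1 (`C#CCCOC(=O)c1ccc(C(CC)(CC)c2ccc(C#CC(O)(CC)CC)c(C)c2)n1CC`) gives > 50000 nM in a functional assay on MCF7 cells (Homo sapiens) for antiproliferative activity, read by MTT assay, with a stated time of 72 h (on this read-out higher numbers stand for weaker inhibition and lower numbers for stronger inhibition), and this is a limit of the assay, not a number. Compound 2 (`CCCCC(=O)c1ccc(C(CC)(CC)c2ccc(C#CC(O)(CC)CC)c(C)c2)n1CC`) gives > 50000 nM in this assay and this too is a limit. Among the measured compounds shown here, compound 3 (`CCn1c(C(=O)N[C@H](C(=O)O)C(C)C)ccc1C(CC)(CC)c1ccc(C#CC(O)(CC)CC)c(C)c1`) gives 13000 nM and so holds the only actual number in the set.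

Compound 4 (`CCn1c(C(=O)NCCCO)ccc1C(CC)(CC)c1ccc(C#CC(O)(CC)CC)c(C)c1`) is still unmeasured. It carries 3-hydroxypropyl in place of 1-carboxy-2-methylpropyl on an amide-type nitrogen.

For the measured compounds named here, two measured steps bear on this change (an at least 3.8-fold lower number from compound 1 to compound 3 (0.58 log units; beyond the scatter); an at least 3.8-fold lower number from compound 2 to compound 3 (0.58 log units; beyond the scatter)). Each starts from a limit and therefore gives only a minimum size. Both bring in the whole (1-carboxy-2-methylpropyl)amino group, and neither separates the amide-type nitrogen from the chain that now leaves.

Compound 4 keeps the amide-type nitrogen of compound 3 at 13000 nM as the only numerical anchor, and it loses the chain, so the expectation is a small drift towards weaker inhibition. A return to the assay limit is still possible for compound 4. The expected change lies within the scatter (a 1.5-fold higher number from compound 3 to compound 4 (0.19 log units; within the scatter)). For compound 4 the estimated value is 20000 nM with an expected range from 6000 nM to 50000 nM in this assay.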

Compound 4, half-maximal inhibitory concentration: 5950 nM
Compound 4: middle estimate off by 3.4-fold (0.53 log units), on the high side, outside the stated range (below it).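

Among the compounds shown here, on the amide-type nitrogen, 3-hydroxypropyl in place of 1-carboxy-2-methylpropyl gives, in this assay, a 2.2-fold lower number from compound 3 to compound 4 (0.34 log units; beyond the scatter), the first step in this set with a real number at both ends, and it shows that neither the carboxylic acid nor the branched chain with its defined stereocentre is required for activity at this position. Against the two compounds without an amide, (3-hydroxypropyl)amino in place of butyl gives an at least 8.4-fold lower number from compound 2 to compound 4 (0.92 log units; beyond the scatter), and in place of (but-3-yn-1-yl)oxy it gives an at least 8.4-fold lower number from compound 1 to compound 4 (0.92 log units; beyond the scatter). These two steps are only minimum sizes because each starts from a limit of the assay and not from a number: the limit of > 50000 nM in this assay, at which 2 of the 4 values shown sit.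

The step from the 1-carboxy-2-methylpropyl chain to the 3-hydroxypropyl chain changes the chain's length, branching and end group all at once, so the compounds shown cannot say which of these changes matters. A plain propyl chain, a longer chain ending in a hydroxyl, an unbranched chain ending in a carboxylic acid, or a chain ending in an amine would each help to separate them.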